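This account rests on a few compounds, and the source may have more. Where it says the series, first, only, none or still open, it means among the compounds named here.

In a functional assay on HeLa cells (Homo sapiens) for antiproliferative activity, read by MTT assay, with a stated time of 48 h (on this read-out lower numbers stand for stronger inhibition of growth and higher numbers for weaker inhibition of growth), three compounds built on a shared core have been measured. Compound 1 `CCCOC(=O)N1N=C(c2ccccc2)CC1c1cc(OC)c(OC)c(OC)c1` gives > 10000 nM, which is a limit of the assay and not a number. Compound 2 `COC(=O)N1N=C(c2cccc(OC)c2)CC1c1cc(OC)c(OC)c(OC)c1` gives 1530 nM, and compound 3 `COC(=O)N1N=C(c2cccc(O)c2)CC1c1cc(OC)c(OC)c(OC)c1` gives 1970 nM. Among the measured compounds shown here, the one measured step is a 1.3-fold higher number from compound 2 to compound 3 (0.11 log units; within the scatter), so compound 3 stands level with compound 2.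

Compound 4 `CCCOC(=O)N1N=C(c2cccc(O)c2)CC1c1cc(OC)c(OC)c(OC)c1` differs from compound 3 in one place: methoxycarbonyl becomes propoxycarbonyl, with ethyl in place of hydrogen on a saturated chain carbon bound to an oxygen next to a carbonyl group. For the measured compounds named here, no measured step covers this change directly, since the step above concerns a different place. Going by the values given here, the only hint comes from compound 1, which also carries propoxycarbonyl but differs from compound 3 elsewhere too. Compound 1 sits at the limit of > 10000 nM. On that weak hint, the expected step is a 2.0-fold higher number from compound 3 to compound 4 (0.31 log units; beyond the scatter), towards weaker inhibition of growth in this assay. For compound 4 the estimated value is 4000 nM, with an expected range of 1500 nM to 10000 nM.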

Compound 4, concentration for 50% growth inhibition: > 10000 nM
Compound 4: only a limit was reported; the forecaster's own chance of this, stated with the estimate: 25%; at least 2.5-fold (0.39 log units) between middle value and limit.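

Replacing methoxycarbonyl with propoxycarbonyl now has a measured effect at this position in this assay: the step is an at least 5.0-fold higher number from compound 3 to compound 4 (0.70 log units; beyond the scatter), towards weaker inhibition of growth. Compound 1 could not show this, as it differs from compound 3 in more than one place, and the step from compound 1 to compound 4 cannot be read, since both values are limits. The value of compound 4 is a limit of the assay and not a number, so the step has a floor but no known full size: the limit of > 10000 nM in this assay, at which 2 of the 4 values shown sit.

From the compounds shown here alone, it remains open how an ethoxycarbonyl group, with a chain shorter than propoxy, would behave at this position. An amide in place of the ester is also untested among the compounds shown, so whether it would keep growth inhibition is unknown.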